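Thiophen-3-yl for furan-3-yl at a limit

The source may hold more compounds than are shown below. What is called first, only, known or untested is meant among the compounds shown, and "the series" means these compounds.

Compound 1 `Nc1nc(N)c2c(-c3ccsc3)cn([C@@H]3O[C@H](CO)[C@@H](O)[C@H]3O)c2n1`: > 20000 nM
Compound 2 `Cc1nc(N)c2c(-c3ccco3)cn([C@@H]3O[C@H](CO)[C@@H](O)[C@H]3O)c2n1`: > 20000 nM
Compound 3 `Cc1nc(N)c2c(-c3ccoc3)cn([C@@H]3O[C@H](CO)[C@@H](O)[C@H]3O)c2n1`: > 20000 nM

All three entries are limits and not numbers. In a functional assay on HeLa S3 cells (Homo sapiens) for antiproliferative activity, read by XTT assay, with a stated time of 72 h (on this read-out higher numbers stand for weaker inhibition and lower numbers for stronger inhibition), compound 3 gives > 20000 nM, which is a limit, so its position is known only as a bound. The other two values shown are limits as well, and the evidence amounts to the limit of > 20000 nM in this assay, at which 3 of the 3 values shown sit.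

The change now followed leads to compound 4 `Cc1nc(N)c2c(-c3ccsc3)cn([C@@H]3O[C@H](CO)[C@@H](O)[C@H]3O)c2n1`, with thiophen-3-yl in place of furan-3-yl on an aromatic carbon.

Among the measured compounds shown here, the one measured step that bears on this exchange of five-membered rings is a step that the two limits leave unreadable from compound 2 to compound 3, with furan-3-yl in place of furan-2-yl on an aromatic carbon. It gives no size to carry over. Compound 1 also carries thiophen-3-yl, and its entry is > 20000 nM, again a limit.

On this basis, no step beyond the usual scatter is expected in this assay, and no direction can be given. The estimated step is a number no higher from compound 3 to compound 4 (the limit leaves the size open). For compound 4 the expected value is 20000 nM, with an estimated range of 6000 nM to 30000 nM, and a report as a limit is the likeliest outcome.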

Compound 4, half-maximal inhibitory concentration: > 20000 nM
Compound 4 was reported as a limit (the forecaster's own chance of this, stated with the estimate: 80%); the middle value sits exactly at the limit.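

In this assay compound 4 gives > 20000 nM, which is a limit, so the steps to it from compound 1, compound 2 and compound 3 cannot be read. The compounds shown leave open whether the thiophen-3-yl, furan-3-yl and furan-2-yl groups differ at all, since every entry is a limit: the limit of > 20000 nM in this assay, at which 4 of the 4 values shown sit.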